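The source may report more compounds than this note shows. Statements on the series, on what has been measured and on what is new or still open speak of the compounds shown alone.

Working notes on the series. Compound 1 `COc1cccc(/C=N/NC(=O)CSc2nnc(-c3ccncc3)o2)c1` shares its core with compound 2 `O=C(CSc1nnc(-c2ccncc2)o1)N/N=C/c1ccccc1O` and compound 3 `O=C(CSc1nnc(-c2ccncc2)o1)N/N=C/c1cc(Br)cc(Br)c1O`, the three differing only in the group on the carbon double-bonded to nitrogen. In an ADME assay on NIH3T3 cells (Mus musculus) for cytotoxicity, read by MTT assay, with a stated time of 24 h (a lower number here means a stronger inhibitor, a higher number a weaker inhibitor), compound 1 gives 179000 nM. In this assay compound 2 gives 155000 nM, and compound 3 gives 190000 nM. Compound 1 thus sits among three numbers that all fall within the scatter of one another: the step of a 1.2-fold lower number from compound 1 to compound 2 (0.06 log units; within the scatter) and the step of a 1.1-fold higher number from compound 1 to compound 3 (0.03 log units; within the scatter) are both within the scatter, as is a 1.2-fold higher number from compound 2 to compound 3 (0.09 log units; within the scatter).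

Compound 4 `O=C(CSc1nnc(-c2ccncc2)o1)N/N=C/C=C/c1ccccc1` is the next step from compound 1, with 2-phenylethenyl in place of 3-methoxyphenyl on a carbon with a double bond to nitrogen. Among the compounds with values here, the three measured steps all concern exchanges of the group at this same position, and none moved the number beyond the scatter; the new group has no counterpart among them, so no other guide is available. The expected step for compound 4 is therefore a 1.0-fold lower number from compound 1 to compound 4 (0.01 log units; within the scatter), none beyond the scatter. Compound 4 is expected at 175000 nM, with a range from 90000 nM to 350000 nM.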

Compound 4, half-maximal inhibitory concentration: 160000 nM
For compound 4 the middle estimate is 1.1-fold (0.04 log units) above the measured one; measured number inside the range.
By their numbers in this assay, from the lowest: compounds 2, 4, 1 and 3 (each within the scatter of the next).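

Compound 4 brings 2-phenylethenyl, with a double bond outside aromatic rings, to the carbon with a double bond to nitrogen, yet every new step in this assay stays within the scatter (a 1.1-fold lower number from compound 1 to compound 4 (0.05 log units; within the scatter); a 1.2-fold lower number from compound 3 to compound 4 (0.07 log units; within the scatter); a 1.0-fold higher number from compound 2 to compound 4 (0.01 log units; within the scatter)). Insensitivity at this position therefore no longer rests on substituted phenyl groups alone, and it holds for all four compounds, with none going against it. Nothing available explains this flat result.

Going by these compounds, it remains open whether an amine, a carboxylic acid or a longer alkyl chain on this carbon would move the number beyond the scatter. Also open, on these data alone, is whether changes elsewhere on the shared core would do so.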